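Compounds 1 to 3: side-chain change at the carbonyl

The source may report more compounds than this note shows. Statements on the series, on what has been measured and on what is new or still open speak of the compounds shown alone.

- compound 1 `COc1ccc(C2=[N+]3C(=Nc4c(-c5ccccc5)c5c(n4[B-]3(F)F)-c3ccc(OCC(=O)O)cc3CC5)C(c3ccccc3)=C2I)cc1` at 142 nM
- compound 2 `COc1ccc(C2=[N+]3C(=Nc4c(-c5ccccc5)c5c(n4[B-]3(F)F)-c3ccc(OCC(=O)N[C@@H](CC(=O)O)C(=O)O)cc3CC5)C(c3ccccc3)=C2I)cc1` at 81 nM

In a toxicity assay on A-375 cells (Homo sapiens) for cytotoxicity, read by CCK-8 assay, with stated times of 16 h and 24 h (on this read-out higher numbers stand for weaker inhibition and lower numbers for stronger inhibition), compound 2 stands within the scatter of compound 1, and the two cannot be ranked. Their step of a 1.8-fold lower number from compound 1 to compound 2 (0.24 log units; within the scatter) came with (1,2-dicarboxyethyl)amino in place of hydroxy on a carbonyl carbon.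

Compound 3 `COc1ccc(C2=[N+]3C(=Nc4c(-c5ccccc5)c5c(n4[B-]3(F)F)-c3ccc(OCC(=O)N[C@@H](CCC(=O)O)C(=O)O)cc3CC5)C(c3ccccc3)=C2I)cc1` differs from compound 2 by carboxymethyl in place of carboxy on a saturated chain carbon, two bonds along the chain from an amide-type nitrogen and a carbonyl carbon with carboxymethyl in place of carboxy on a saturated chain carbon, two bonds along the chain from an amide-type nitrogen and a carbonyl carbon. The side chain thus reads (1,3-dicarboxypropyl)amino.

Going by the values given here, no measured step covers this exact change. The closest evidence is the step of a 1.8-fold lower number from compound 1 to compound 2 (0.24 log units; within the scatter) in the same side chain, so no shift beyond the scatter is expected in this assay and no direction is favoured. The estimated change is a 1.1-fold higher number from compound 2 to compound 3 (0.05 log units; within the scatter) and it should not be read as a trend. Compound 3 is estimated at 90 nM with an expected range from 40 nM to 200 nM in this read-out.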

Compound 3, half-maximal inhibitory concentration in the A-375 assay: 166 nM
Compound 3: middle estimate off by 1.8-fold (0.27 log units), on the low side; the measured number falls inside the stated range.
By their numbers in the A-375 assay, from the lowest: compounds 2, 1 and 3 (each within the scatter of the next, the first and the last beyond it).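

Going by these compounds alone, in the A-375 assay compound 2 gives 81 nM and compound 3 gives 166 nM and the change from 1,2-dicarboxyethyl to 1,3-dicarboxypropyl gives a 2.0-fold higher number from compound 2 to compound 3 (0.31 log units; beyond the scatter) and is the first step in this side chain to pass the scatter, so this position does respond to the change, if only modestly. Measured against the free acid in the A-375 assay the same side chain gives a 1.2-fold higher number from compound 1 to compound 3 (0.07 log units; within the scatter) and so cannot be ranked against hydroxy on the carbonyl carbon. In a physicochemical assay for lipophilicity (on this read-out lower numbers stand for lower lipophilicity and higher numbers for higher lipophilicity), compound 2 gives -0.77 and compound 3 gives -0.74 and the pair shows a number 0.03 log units higher from compound 2 to compound 3 (within the scatter) and is not separated, and no supporting data account for the difference between compound 2 and compound 3 in the A-375 assay.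

Going by these compounds, whether a longer chain bearing the carboxylic acid would move the number further remains open. So does the outcome of an amine in place of that carboxylic acid.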